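The compounds below may be only part of what the source reports. "The series", "measured", "known", "first", "only" and "open" are said of these compounds alone.

In an ADME assay on microsomes from liver (Homo sapiens) for metabolic stability, read by LC-MS, with a stated time of 1 h (on this read-out higher numbers stand for a more stable compound and lower numbers for a less stable compound), compound 3 `COc1cccc(F)c1-c1ccc(CO[C@@H]2COc3nc([N+](=O)[O-])cn3C2)cc1` gives 91%, the highest of the three numbers, against compound 1 `CCOc1ccccc1-c1ccc(CO[C@@H]2COc3nc([N+](=O)[O-])cn3C2)cc1` at 50% and compound 2 `CC(=O)c1ccc(-c2ccc(CO[C@@H]3COc4nc([N+](=O)[O-])cn4C3)cc2)cc1` at 36%. Compound 4 `COc1ccc(-c2ccc(CO[C@@H]3COc4nc([N+](=O)[O-])cn4C3)cc2)cc1F` differs from compound 3 by 3-fluoro-4-methoxyphenyl in place of 2-fluoro-6-methoxyphenyl on an aromatic carbon: 3-fluoro-4-methoxyphenyl in place of 2-fluoro-6-methoxyphenyl, para to a large group. Two large measured steps change this same aryl group: a number 41 percentage points higher from compound 1 to compound 3 (beyond the scatter) and a number 55 percentage points higher from compound 2 to compound 3 (beyond the scatter). The smaller step, a number 14 percentage points lower from compound 1 to compound 2 (beyond the scatter), shows a lower number with another group at this place. Among the three measured compounds, only the one with 2-fluoro-6-methoxyphenyl stands high, so a large fall is expected in this assay. The expected change is a number 33 percentage points lower from compound 3 to compound 4 (beyond the scatter). Compound 4 is estimated at 58%, with an expected range of 35% to 80%.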

Compound 4, percent of the compound remaining: 80%
Compound 4: the middle estimate sits 22 percentage points below what was measured; the range from low to high includes it.
By their numbers in this assay, from the lowest: compound 2; then compound 1; then compound 4; then compound 3.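

In this assay the change of isomer gives a number 11 percentage points lower from compound 3 to compound 4 (beyond the scatter) with the same atoms joined differently, so a high number is not confined to 2-fluoro-6-methoxyphenyl. 3-Fluoro-4-methoxyphenyl also stands clear of the other two aryl groups, with a number 44 percentage points higher from compound 2 to compound 4 (beyond the scatter) and a number 30 percentage points higher from compound 1 to compound 4 (beyond the scatter) at this place. No data at hand account for these steps.

Open, going by these compounds, is whether a lone fluorine or a lone methoxy on this aryl ring would hold the number, and how an amine or a carboxylic acid there would read.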